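Adding a Methoxy Group to Two Related Amides

This account rests on a few compounds, and the source may have more. Where it says the series, first, only, none or still open, it means among the compounds named here.

Measured so far:
- compound 1, `COc1ccc(NC(=O)CCc2cccc3c2B(O)OC3)cc1`: 900 nM
- compound 2, `COc1ccc(NC(=O)CCc2cccc3c2B(O)OC3)cc1OC`: > 100000 nM
- compound 3, `COc1cccc(-c2cccc(NC(=O)CCc3ccc4c(c3)B(O)OC4)c2)c1`: 62000 nM

All three were tested in a functional assay on SK-OV-3 cells (Homo sapiens) for antiproliferative activity, read by MTT assay, with a stated time of 72 h; a lower number here means a stronger inhibitor, a higher number a weaker inhibitor. Compound 1 gives 900 nM in this assay. Compound 2 gives > 100000 nM, which is a limit of the assay and not a number. The change from compound 1 to compound 2 is methoxy in place of hydrogen on an aromatic carbon, and it produced an at least 110-fold higher number from compound 1 to compound 2 (2.04 log units; beyond the scatter). The true size of that step is known only as a lower bound because one value sits at the limit of > 100000 nM in this assay, at which 1 of the 3 values shown sits.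

Compound 3 gives 62000 nM in this assay, the weakest of the two numbers measured. The difference between the cores of compound 1 and compound 3 is not broken down here.

Compound 4, `COc1cc(OC)cc(-c2cccc(NC(=O)CCc3ccc4c(c3)B(O)OC4)c2)c1`, has not yet been measured. It differs from compound 3 by methoxy in place of hydrogen on an aromatic carbon. For the measured compounds named here, this is the same kind of change as the one from compound 1 to compound 2, though the surroundings differ: in compound 2 the new group sits ortho to a methoxy group and meta to a large group, whereas in compound 4 it sits meta to a large group and meta to a methoxy group.

In this assay the expected step is a 2.4-fold higher number from compound 3 to compound 4 (0.38 log units; beyond the scatter), resting on the measured step of an at least 110-fold higher number from compound 1 to compound 2 (2.04 log units; beyond the scatter). Compound 4 is therefore expected to give about 150000 nM, estimated to fall between 40000 nM and 600000 nM, with a real chance that only a limit is reported.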

Compound 4, half-maximal inhibitory concentration: 29000 nM
Estimate against measurement, compound 4: 5.2-fold (0.71 log units) above, outside the stated range (below it).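

In this assay, going by these compounds, the added methoxy group gave a 2.1-fold lower number from compound 3 to compound 4 (0.33 log units; beyond the scatter), a move in the opposite direction to the earlier step, so the same change did not carry over from one core to the other with its size or its direction intact: the same change on two cores in this assay, an at least 110-fold higher number (2.04 log units; beyond the scatter) from compound 1 to compound 2 and a 2.1-fold lower number (0.33 log units; beyond the scatter) from compound 3 to compound 4, at least 230-fold (2.37 log units) apart, beyond the scatter of two such steps The earlier step ends on compound 2, whose > 100000 nM is a limit of the assay and not a number, so that step has no known end point, and how far the two steps really lie apart stays open as well. Two pairs are too few to give a rule, and they do not show whether the split follows from the core or from where the new methoxy group sits, as both differ between the pairs.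

The compounds shown leave open whether the shift from 3-methoxyphenyl to 3,5-dimethoxyphenyl is special to methoxy, which a hydroxy group, an amine or a chlorine in the same place on compound 3 would help to test. They also leave open which way the same methoxy change would go on a third core in this series.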